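This account rests on a few compounds, and the source may have more. Where it says the series, first, only, none or still open, it means among the compounds named here.

Working notes on the benzofuran-free description: the shared core of compound 3 `CC(=O)N[C@H]1CCN(c2cccc3oc(CCCCc4ccccc4)cc23)C1` carries a 3-acetamidopyrrolidin-1-yl group, and in an assay on NIH3T3 cells for binding affinity to melatonin receptor type 1B (Homo sapiens) (a lower number here means a stronger inhibitor, a higher number a weaker inhibitor), compound 3 gives 14 nM. Among the compounds with values here, that places compound 3 second highest of the three numbers so far. Compound 1 `CCC(=O)NC[C@@H]1CC1c1cccc2oc(CCCCc3ccccc3)cc12` gives 2.8 nM in this assay, and the step of a 5.0-fold higher number from compound 1 to compound 3 (0.70 log units; beyond the scatter) is modest. Compound 2 `CCCC(=O)NCCCc1cccc2oc(CCCCc3ccccc3)cc12` gives 82 nM in this assay; the step of a 5.9-fold lower number from compound 2 to compound 3 (0.77 log units; beyond the scatter) is modest, and the step of a 29-fold higher number from compound 1 to compound 2 (1.47 log units; beyond the scatter) is the largest in the set.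

Compound 4 `CC(C)C(=O)N[C@H]1CCN(c2cccc3oc(CCCCc4ccccc4)cc23)C1` differs from compound 3 only by isopropyl in place of methyl on a carbonyl carbon. Within the data shown here, no measured step bears on this change: each of the three steps above exchanges the whole side chain on the aromatic carbon, and none varies the acyl group on the amide nitrogen while holding the rest fixed. With nothing to argue for a shift in either direction, the step of a 1.1-fold higher number from compound 3 to compound 4 (0.03 log units; within the scatter) is expected to stay within the scatter. Compound 4 is therefore estimated at 15 nM in this assay, with a range from 5 nM to 45 nM.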

Compound 4, inhibition constant: 162 nM
Beside the measured number, compound 4's estimate is 11-fold (1.03 log units) below it; measured number above the stated range.
By their numbers in this assay, from the lowest: compound 1; then compound 3; then compounds 2 and 4 (each within the scatter of the next).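

In this assay, within the data shown here, the group on the carbonyl carbon proves to be a sensitive position: isopropyl in place of methyl gives a 12-fold higher number from compound 3 to compound 4 (1.06 log units; beyond the scatter), whereas the earlier steps exchanged the whole side chain on the aromatic carbon and left this group's contribution unresolved. On the shared core with the pyrrolidine side chain, a change confined to the acyl end of the amide is therefore enough to produce a large step, although this rests on a single pair. The data shown hold nothing that accounts for the size of this step.

Still open, going by these compounds, is whether a cyclopropyl or a tert-butyl group on this carbonyl carbon would track with isopropyl or stay closer to methyl. Also open, on these data alone, is whether the same methyl-to-isopropyl exchange would give a step of similar size on the side chains of compound 1 and compound 2.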